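The source may hold more compounds than are shown below. What is called first, only, known or untested is meant among the compounds shown, and "the series" means these compounds.

The series centres on a shared core carrying a propenone-linked aryl group, and compound 1 `COc1cccc(COc2ccc3cc(C(=O)/C=C/c4cc(OC)ccc4OC)c(=O)oc3c2)c1` is the reference point for the step that follows. In a functional assay on MOLT-4 cells (Homo sapiens) for cytotoxicity, read by MTT assay, with a stated time of 72 h (on this read-out lower numbers stand for stronger inhibition and higher numbers for weaker inhibition), compound 1 gives 13800 nM, the highest of the three numbers recorded. Among the measured compounds shown here, compound 2 `COc1cccc(/C=C/C(=O)c2cc3cc(O)ccc3oc2=O)c1OC` gives 6700 nM in this assay, and compound 3 `COC(=O)c1ccc(/C=C/C(=O)c2cc3ccc(O)cc3oc2=O)cc1` gives 3700 nM, so both stand below compound 1 by margins that exceed the scatter of repeated measurements; no single-point steps link them to compound 1, so only their values can be compared.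

Compound 4 `COc1cccc(COc2ccc3cc(C(=O)/C=C/c4ccccc4)c(=O)oc3c2)c1` has not yet been measured. It differs from compound 1 in one place: phenyl in place of 2,5-dimethoxyphenyl on a double-bonded chain carbon bound to a double-bonded chain carbon. With no measured step of this kind in the set, the size of the change is uncertain; the reference compounds suggest any movement is more likely downward than upward, but a step no larger than the scatter is also expected as plausible. The step from compound 1 to compound 4 is estimated at a 1.5-fold lower number from compound 1 to compound 4 (0.19 log units; within the scatter). Compound 4 is therefore expected to give about 9000 nM in this assay, between 3000 nM and 27000 nM.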

Compound 4, half-maximal inhibitory concentration: > 100000 nM
Compound 4 ended at the assay's limit; the forecaster's own chance of this, stated with the estimate: 10%; middle value at least 11-fold (1.04 log units) away from the limit.
By their numbers in this assay, from the lowest: compounds 3 and 2 (each within the scatter of the next); then compound 1. At a limit, above all of these: compound 4.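

In this assay, phenyl in place of 2,5-dimethoxyphenyl on a double-bonded chain carbon bound to a double-bonded chain carbon gives an at least 7.2-fold higher number from compound 1 to compound 4 (0.86 log units; beyond the scatter). Among the compounds shown here, this is the only step in the set that can be read, and it shows that the change at this place moves the read-out upward, beyond the scatter, so the two methoxy groups of compound 1 cannot be dropped together without a clear loss of inhibition. Compound 4 stands at a limit of the assay, > 100000 nM, so the true size of the step remains unknown: the limit of > 100000 nM in this assay, at which 1 of the 4 values shown sits.

The compounds shown leave open whether a phenyl carrying a single methoxy group would keep the inhibition of compound 1, or whether a hydroxyl or a fluorine could take the place of methoxy. Going by these compounds, it also stays open whether the same change would act alike on the hydroxyl-bearing core of compound 2.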